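A few compounds are considered here, and "the series" means these few. Any claim that something is new, unique, unknown or untested is made for them only; others in the source may bear on it.

Measured so far in a functional assay on the whole organism for activation, with Mus musculus as the target; a higher number here means that more compound is needed for the effect, a lower number that less compound is needed:

- compound 1 `Nc1ncnc2c1nc(O)n2Cc1ccc(Cl)cc1`: 30 mg/kg
- compound 2 `CCCCOc1nc(N)c2[nH]c(=O)n(Cc3ccccc3)c2n1`: 0.1 mg/kg
- compound 3 `Cc1nc(N)c2nc(O)n(Cc3ccccc3)c2n1`: 3 mg/kg

Compound 3 stands second highest of the three numbers. Its nearest neighbour is compound 1, whose value of 30 mg/kg is higher by a gap beyond the scatter. The furthest is compound 2, whose value of 0.1 mg/kg is lower by a gap well beyond the scatter; compound 2 also carries a longer group on the shared core than compound 3 does.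

The next compound is compound 4 `CCCc1nc(N)c2nc(O)n(Cc3ccccc3)c2n1`. Its difference from compound 3 is ethyl in place of hydrogen on a saturated chain carbon bound to an aromatic carbon. Among the compounds with values here, no step between two measured compounds isolates this change, so the expectation rests on compound 2, which carries the longest substituent at a comparable part of the core and gives the lowest number of the three.

The step of a 4.3-fold lower number from compound 3 to compound 4 (0.63 log units; beyond the scatter) is expected to lower the number by a moderate amount, clearly beyond the scatter. For compound 4 the estimated value is 0.7 mg/kg, with a range from 0.15 mg/kg to 3 mg/kg.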

Compound 4, minimum effective dose: 3 mg/kg
Beside the measured number, compound 4's estimate is 4.3-fold (0.63 log units) below it; measured number inside the range.
By their numbers in this assay, from the lowest: compound 2; then compounds 3 and 4 (each within the scatter of the next); then compound 1.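

In this assay, lengthening the group on this saturated chain carbon from methyl to propyl gives no change at the digits printed from compound 3 to compound 4 (within the scatter), so this change alone does not move the dose needed. The earlier compounds shown here could not show this, as no pair among them isolated the chain at this position. No measurement on hand bears on why the number stays flat.

Still open, as far as these compounds go, is whether a butyl chain or a branched group such as isopropyl at this position would shift the number, or whether the flat response continues. Also open, from the compounds shown here alone, is whether an ether oxygen joining the chain to the shared core, as in the butoxy group of compound 2 with 0.1 mg/kg, matters more than chain length, which would need a propoxy or methoxy analogue to test.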